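The source may hold more compounds than are shown below. What is called first, only, known or untested is meant among the compounds shown, and "the series" means these compounds.

In an ADME assay on microsomes from liver (Homo sapiens) for metabolic stability (a higher number here means that the compound lasts longer, a lower number that the compound disappears faster), compound 1 (`CC(C)C(/C=C1\NC(=O)NC1=O)c1ccc(-c2ccc3cccc(F)c3c2)[nH]c1=O`) gives > 3 h, which is a limit of the assay and not a number. Compound 2 (`CC(C)C(/C=C1\SC(=O)NC1=O)c1ccc(-c2ccc3cccc(F)c3c2)[nH]c1=O`) gives > 3 h, again a limit. Within the data shown here, compound 3 (`CC(C)C(c1ccc(-c2ccc3cccc(F)c3c2)[nH]c1=O)C1C(=O)NC(=O)N1C`) gives 0.375 h, the only actual number. Compound 4 (`CC(C)C(/C=C1/C(=O)NC(=O)N1C)c1ccc(-c2ccc3cccc(F)c3c2)[nH]c1=O`) differs from compound 3 by one change: a group of 9 heavy atoms (5 carbon, 2 nitrogen, 2 oxygen; one five-membered non-aromatic ring with 2 hetero atoms) in place of a group of 8 heavy atoms (4 carbon, 2 nitrogen, 2 oxygen; one five-membered non-aromatic ring with 2 hetero atoms), on a saturated chain carbon bound to an aromatic carbon and a saturated chain carbon. Among the measured compounds shown here, two measured steps bear on this change: an at least 8.0-fold lower number from compound 1 to compound 3 (0.90 log units; beyond the scatter) and an at least 8.0-fold lower number from compound 2 to compound 3 (0.90 log units; beyond the scatter). Their sizes rest on (the limit of > 3 h in this assay, at which 2 of the 3 values shown sit), so they are minimum sizes only. Like compound 1 and compound 2, compound 4 carries a double bond outside its five-membered ring that compound 3 lacks, although its methyl group is shared with compound 3 alone. Part of the drop seen on reaching compound 3 is therefore expected to be recovered in this assay, and the expected change is a 4.0-fold higher number from compound 3 to compound 4 (0.60 log units; beyond the scatter). For compound 4 the estimated half-life is 1.5 h, with an expected range from 0.5 h to 4 h.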

Compound 4, half-life: > 3 h
Compound 4: no number, only a limit; the forecaster's own chance of this, stated with the estimate: 35%; middle value at least 2.0-fold (0.30 log units) from the limit.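

In this assay, the change from the 3-methyl-2,5-dioxoimidazolidin-4-yl group to the group with one more double bond outside aromatic rings gives an at least 8.0-fold higher number from compound 3 to compound 4 (0.90 log units; beyond the scatter). The methyl group that compound 4 shares with compound 3 therefore does not by itself go with the short half-life of compound 3, since compound 4 carries that methyl group as well. The steps from compound 1 and from compound 2 to compound 4 cannot be read, and the one readable step gives a minimum size only: the limit of > 3 h in this assay, at which 3 of the 4 values shown sit.

From the compounds shown here alone, how compound 1, compound 2 and compound 4 rank against one another in this assay stays open. The compounds shown also do not tell whether an ethyl group or a longer chain in place of the methyl group would leave the half-life at this limit.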